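A Cyclohexyl Amide Follows Two Aryl Amides

The compounds below may be only part of what the source reports. "The series", "measured", "known", "first", "only" and "open" are said of these compounds alone.

Compound 2 `O=C(Nc1ccc(Cl)cc1CN1C(=O)c2ccccc2C1=O)c1ccccc1C(F)(F)F` shares its core with compound 1 `O=C(Nc1ccc(Cl)cc1CN1C(=O)c2ccccc2C1=O)c1ccccc1[N+](=O)[O-]`; the two differ only in the group on the aromatic ring of the amide. In an assay on CHO cells for positive allosteric modulation of metabotropic glutamate receptor 5 (Homo sapiens), read by FLIPR (a higher number here means that more compound is needed for the effect, a lower number that less compound is needed), compound 1 gives 5700 nM, and in this assay compound 2 gives 5700 nM. The step of no change at the digits printed from compound 1 to compound 2 (within the scatter) thus leaves the reading where it was, and compound 2 stands level with compound 1.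

Compound 3 `O=C(Nc1ccc(Cl)cc1CN1C(=O)c2ccccc2C1=O)C1CCCCC1` takes the next step: cyclohexyl in place of 2-(trifluoromethyl)phenyl on a carbonyl carbon. For the measured compounds named here, no measured pair mirrors this exchange. Going by the values given here, the one step in hand, no change at the digits printed from compound 1 to compound 2 (within the scatter), swapped one aromatic substituent for another and did not move the reading; it says nothing about removing the aromatic ring altogether in favour of a saturated one. The account therefore has no basis for a direction, and the expected step in this assay is small, with a wide margin either way.

For compound 3 the estimate in this assay is 7000 nM, within a range of 1500 nM to 40000 nM, which amounts to an expected step of a 1.2-fold higher number from compound 2 to compound 3 (0.09 log units; within the scatter).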

Compound 3, half-maximal effective concentration: 1500 nM
For compound 3 the middle estimate is 4.7-fold (0.67 log units) above the measured one; low and high end bracket the measured number.
By their numbers in this assay, from the lowest: compound 3; then compounds 1 and 2 (each within the scatter of the next).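

The group on the carbonyl carbon turns out to be a place where the reading can move. In this assay, the exchange of nitro for trifluoromethyl on the aromatic ring gave no change at the digits printed from compound 1 to compound 2 (within the scatter), whereas cyclohexyl in place of 2-(trifluoromethyl)phenyl gives a 3.8-fold lower number from compound 2 to compound 3 (0.58 log units; beyond the scatter) and cyclohexyl in place of 2-nitrophenyl gives a 3.8-fold lower number from compound 1 to compound 3 (0.58 log units; beyond the scatter), so that both aryl amides need more compound than the cyclohexyl amide and an aromatic ring on the carbonyl is not required for the effect in this short series. Nothing in the material shown accounts for this difference between the aryl amides and the cyclohexyl amide.

As far as these compounds go, whether the lower number goes with the saturated ring itself or with the loss of the substituent on the aromatic ring remains open, and an unsubstituted phenyl on the carbonyl carbon would be the comparison that separates the two. Also open, from the compounds shown here alone, is how far this position reaches beyond a single saturated ring, for instance how a cyclopentyl, a longer alkyl chain, or a cyclohexyl ring carrying a hydroxyl or an amine would read.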